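A few compounds are considered here, and "the series" means these few. Any claim that something is new, unique, unknown or untested is made for them only; others in the source may bear on it.

Measured in a functional assay on HCT-116 cells (Homo sapiens) for inhibition, read by MTT assay, with a stated time of 48 h; on this read-out higher numbers stand for weaker inhibition and lower numbers for stronger inhibition:
- compound 1 `COc1ccc(C(=O)CSc2nnc(-c3cc(OC)c(OC)c(OC)c3)n2-c2ccc(OC)cc2)cc1`: > 60000 nM, a limit of the assay and not a number
- compound 2 `COc1cc(-c2nnc(SCC(=O)c3ccccc3)n2-c2ccc(N(C)C)cc2)cc(OC)c1OC`: 42500 nM

Going by the values given here, compound 2 holds the only true number in this small set, at 42500 nM. The other result offers no exact reference point, as the limit of > 60000 nM in this assay, at which 1 of the 2 values shown sits, is a limit.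

The next compound to be read is compound 3 `COc1ccc(C(=O)CSc2nnc(-c3cc(OC)c(OC)c(OC)c3)n2-c2ccc(N(C)C)cc2)cc1`. It differs from compound 2 by methoxy in place of hydrogen on an aromatic carbon, which turns the phenyl of the benzoyl group into 4-methoxyphenyl. The methoxy sits on an aromatic carbon, para to a large group.

Among the compounds with values here, no measured pair shows the size of this kind of change, so the expectation has little to rest on. No step beyond the usual scatter is expected in this assay, and no direction is favoured with any confidence. The expected change is a 1.1-fold lower number from compound 2 to compound 3 (0.05 log units; within the scatter). For compound 3 the estimated value is 38000 nM. The expected range for compound 3 runs from 15000 nM to 80000 nM.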

Compound 3, half-maximal inhibitory concentration: > 60000 nM
Compound 3 gave a limit, no number; the forecaster's own chance of this, stated with the estimate: 35%; middle value at least 1.5-fold (0.19 log units) from the limit.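

In this assay, going by these compounds alone, the change from phenyl to 4-methoxyphenyl gives the first single-place comparison: an at least 1.4-fold higher number from compound 2 to compound 3 (0.14 log units; that floor lies within the scatter). This step is only a floor, so it does not separate methoxy from hydrogen at this position, but it does show that methoxy para to a large group brings no lower number. Compound 3 gives > 60000 nM, which is a limit of the assay and not a number, and the step between the two limit compounds, compound 1 and compound 3, cannot be read, so dimethylamino in place of methoxy on an aromatic carbon has no size here: the limit of > 60000 nM in this assay, at which 2 of the 3 values shown sit.

From the compounds shown here alone, the true value of compound 3 remains open. Going by these compounds, compound 2 gives 42500 nM, and whether any group at this position can bring the number clearly lower remains open as well. A fluorine, an amine or a carboxylic acid in place of the methoxy would test this position further, while a number for a compound carrying methoxy on the aromatic carbon where compound 3 has dimethylamino, with hydrogen in place of the benzoyl methoxy, would give that swap a readable size.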